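A few compounds are considered here, and "the series" means these few. Any claim that something is new, unique, unknown or untested is made for them only; others in the source may bear on it.

In a functional assay on MCF7 cells (Homo sapiens) for antiproliferative activity, read by MTT assay, with a stated time of 48 h (a higher number here means a weaker inhibitor, a lower number a stronger inhibitor), compound 1 `COc1ccc(-c2nc(C)c(C(=O)CSc3nc(N)c(C#N)c(-c4ccccc4)n3)s2)cc1` gives 72100 nM, while compound 2 `COc1ccc(-c2nc(SCC(=O)c3sc(-c4ccc(Cl)cc4)nc3C)nc(N)c2C#N)cc1` gives 10100 nM, the lower of the two numbers and beyond the usual scatter of compound 1. Compound 3 `Cc1nc(-c2ccc(Cl)cc2)sc1C(=O)CSc1nc(N)c(C#N)c(-c2ccccc2)n1` has not yet been measured. Relative to compound 2, it has hydrogen in place of methoxy on an aromatic carbon. Within the data shown here, no measured pair shows this change alone, so the expectation is tentative. The expected step is a 1.8-fold higher number from compound 2 to compound 3 (0.25 log units; within the scatter), a modest move towards weaker inhibition. Compound 3 is estimated at 18000 nM, with an expected range of 6000 nM to 55000 nM.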

Compound 3, half-maximal inhibitory concentration: 25200 nM
Compound 3: the middle estimate sits 1.4-fold (0.15 log units) below what was measured; measured number inside the range.
By their numbers in this assay, from the lowest: compound 2; then compound 3; then compound 1.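

In this assay, going from 4-methoxyphenyl to phenyl gives a 2.5-fold higher number from compound 2 to compound 3 (0.40 log units; beyond the scatter), so at this place methoxy goes with the lower number. Chloro in place of methoxy on the other aromatic ring gives a 2.9-fold lower number from compound 1 to compound 3 (0.46 log units; beyond the scatter), so there methoxy goes with the higher number, and the same group points in opposite directions on the two rings. No measurement at hand accounts for this difference. Each direction rests on a single pair. Going by these compounds, whether a hydroxy group or an amine at the methoxy place would match methoxy or hydrogen remains open.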